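The source may hold more compounds than are shown below. What is called first, only, known or untested is meant among the compounds shown, and "the series" means these compounds.

Measured in a functional assay on J82 cells (Homo sapiens) for cytotoxicity, read by colorimetric assay and MTT assay; on this read-out higher numbers stand for weaker inhibition and lower numbers for stronger inhibition:

- Compound 1 `CCOC(=O)Cn1c(=O)c(-c2ccc(OC)cc2)cc2c(OC)cc(OC)cc21`: 10000 nM
- Compound 2 `COc1ccc(-c2cc3c(OC)cc(OC)cc3n(CC(=O)OCc3ccccc3)c2=O)cc1`: 10000 nM
- Compound 3 `COc1ccc(-c2cc3c(OC)cc(OC)cc3n(CC(=O)O)c2=O)cc1`: 10000 nM

Compound 3 stands level with the other two compounds, and all three share the same reading. The next compound is compound 4 `CCN(CC)C(=O)CCn1c(=O)c(-c2ccc(OC)cc2)cc2c(OC)cc(OC)cc21`, and its difference from compound 3 is (diethylcarbamoyl)methyl in place of carboxy on a saturated chain carbon bound to an aromatic nitrogen. In words, (diethylcarbamoyl)methyl comes in place of carboxy on a saturated chain carbon bound to an aromatic nitrogen. Cut one bond further out, this reads carboxymethyl to 2-(diethylcarbamoyl)ethyl.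

Among the compounds with values here, three measured steps bear on this end of the molecule: no change at the digits printed from compound 1 to compound 2 (within the scatter), no change at the digits printed from compound 1 to compound 3 (within the scatter) and no change at the digits printed from compound 2 to compound 3 (within the scatter). Within the data shown here, none of the measured compounds carries an amide here, so this guidance is indirect. Still, with all three of those steps inside the scatter, no step beyond the scatter is expected in this assay, in either direction. The expected step is no change at the digits printed from compound 3 to compound 4 (within the scatter). For compound 4 the estimate is 10000 nM, with an expected range of 4000 nM to 20000 nM.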

Compound 4, half-maximal inhibitory concentration: 10000 nM
For compound 4 middle estimate and measured number coincide at the digits printed; measured number inside the range.
By their numbers in this assay, from the lowest: compounds 1, 2, 3 and 4 (each within the scatter of the next).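

Within the data shown here, compound 4 is the first compound here with an amide at this end of the molecule, yet this assay shows no change at the digits printed from compound 3 to compound 4 (within the scatter). The same holds against the two esters, with no change at the digits printed from compound 2 to compound 4 (within the scatter) and no change at the digits printed from compound 1 to compound 4 (within the scatter). On this saturated chain carbon bound to an aromatic nitrogen, then, 2-(diethylcarbamoyl)ethyl reads the same as the carboxymethyl, benzyloxycarbonyl and ethoxycarbonyl end groups, although this step alters the end group and the chain length together, and the two cannot be told apart.

Still open, going by these compounds, is whether a basic amine such as 2-(dimethylamino)ethyl, a secondary amide or a longer chain at this position would shift the reading, or whether only a change on the shared core would. Nothing measured here explains why these readings coincide.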